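A few compounds are considered here, and "the series" means these few. Any claim that something is new, unique, unknown or untested is made for them only; others in the source may bear on it.

Measured compounds: compound 1 `CCCN(CCC(F)(F)F)Cc1c(C(F)(F)F)nc2n(-c3c(C)cc(C)cc3C)c(Cl)cn12`, 12 nM; compound 2 `CCCN(Cc1c(C(F)(F)F)nc2n(-c3c(C)cc(C)cc3C)c(Cl)cn12)CC1CCC1`, 5.3 nM; compound 3 `CCCN(Cc1ccc(Cl)cc1)Cc1c(C(F)(F)F)nc2n(-c3c(C)cc(C)cc3C)c(Cl)cn12`, 28 nM, all in an assay on cells for displacement of a labelled ligand from corticotropin-releasing factor receptor 1 (Homo sapiens), with a stated time of 100 min; a lower number here means a stronger inhibitor, a higher number a weaker inhibitor.

Compound 3 stands at the highest number of the three in this assay: the steps to it are a 2.3-fold higher number from compound 1 to compound 3 (0.37 log units; beyond the scatter) and a 5.3-fold higher number from compound 2 to compound 3 (0.72 log units; beyond the scatter), while between the other two there is a 2.3-fold lower number from compound 1 to compound 2 (0.35 log units; beyond the scatter). Compound 4 `CCCN(Cc1ccc([N+](=O)[O-])cc1)Cc1c(C(F)(F)F)nc2n(-c3c(C)cc(C)cc3C)c(Cl)cn12` differs from compound 3 by nitro in place of chloro on an aromatic carbon. Among the compounds with values here, none of the measured steps alters a group on that ring; all three exchange the whole substituent on the amine nitrogen, and each of those gave only a modest step. Within the data shown here, with no direct precedent, only a small step is expected, a 1.3-fold higher number from compound 3 to compound 4 (0.10 log units; within the scatter). Compound 4 is therefore estimated at 35 nM in this assay, within 12 nM to 100 nM.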

Compound 4, inhibition constant: 150 nM
Beside the measured number, compound 4's estimate is 4.3-fold (0.63 log units) below it; the whole stated range lies below it.
By their numbers in this assay, from the lowest: compound 2; then compound 1; then compound 3; then compound 4.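

In this assay, changing one group on the aromatic ring, para to a large group, gives a 5.4-fold higher number from compound 3 to compound 4 (0.73 log units; beyond the scatter), so this position is not indifferent to the group it carries. The 4-nitrophenyl group also produces the only large steps among these amine substituents: a 28-fold higher number from compound 2 to compound 4 (1.45 log units; beyond the scatter) and a 13-fold higher number from compound 1 to compound 4 (1.10 log units; beyond the scatter). No measurement here bears on the reason for the rise. The compounds shown leave open whether a nitrile, a methoxy group or an amine at this place would behave like nitro or like chloro. They also leave open how a plain phenyl ring, with no group at this place, would compare.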